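Removing the ring-nitrogen substituent of compound 1

The source may report more compounds than this note shows. Statements on the series, on what has been measured and on what is new or still open speak of the compounds shown alone.

In an assay on CHO cells for displacement of a labelled ligand from 5-hydroxytryptamine receptor 1B (Homo sapiens) (on this read-out higher numbers stand for weaker inhibition and lower numbers for stronger inhibition), compound 1 `c1coc(CN2CCN(CCCc3c[nH]c4ccc(-n5cnnc5)cc34)CC2)c1` gives 18 nM, which is the only single number shown for it; one further entry for compound 1 carries no single number. Compound 2 `NC(=O)C(c1ccccc1)N1CCN(CCCc2c[nH]c3ccc(-n4cnnc4)cc23)CC1` has more than one entry in this assay, 55 nM; 13 nM (2 entries), as shown by the several entries of compound 2 in this assay, 55 nM; 13 nM (2 entries). Compound 3 `c1cc2[nH]cc(CCCN3CCNCC3)c2cc1-n1cnnc1` differs from compound 1 by hydrogen in place of (furan-2-yl)methyl on an amine nitrogen in a ring. Within the data shown here, no measured pair shows this step, so its size must be guessed: a loss of inhibition beyond the scatter is expected, a 4.4-fold higher number from compound 1 to compound 3 (0.65 log units; beyond the scatter). Compound 3 is therefore estimated at 80 nM, with a range from 25 nM to 300 nM.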

Compound 3, half-maximal inhibitory concentration: 145 nM
The estimate for compound 3 lay 1.8-fold (0.26 log units) below the measured number; measured number inside the range.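

Replacing (furan-2-yl)methyl with hydrogen on the amine nitrogen in the ring gives an 8.1-fold higher number from compound 1 to compound 3 (0.91 log units; beyond the scatter) in this assay, so this substituent contributes to inhibition on this core. Compound 3 still shows measurable inhibition with only hydrogen at this position, so the substituent is not essential. The size of the step remains approximate, as repeat entries of one compound can lie well apart: the several entries of compound 2 in this assay, 55 nM; 13 nM (2 entries)

As far as these compounds go, it remains open whether a methyl or a benzyl group on this nitrogen would match compound 1. From the compounds shown here alone, the role of the furan ring itself also remains open.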